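Methyl position on the pyridin-3-yl group: compound 2 to compound 3

A few compounds are considered here, and "the series" means these few. Any claim that something is new, unique, unknown or untested is made for them only; others in the source may bear on it.

Among the measured compounds shown here, compound 2 `Cc1ncccc1-c1cc(F)cc(-n2nnc(-c3ccccn3)n2)c1` gives 41 nM in a functional assay for antagonist activity at metabotropic glutamate receptor 5 (Rattus norvegicus) (a lower number here means a stronger inhibitor, a higher number a weaker inhibitor), the highest of the two numbers measured so far; compound 1 `Nc1ccccc1-c1cc(F)cc(-n2nnc(-c3ccccn3)n2)c1` gives 8 nM, and the step of a 5.1-fold higher number from compound 1 to compound 2 (0.71 log units; beyond the scatter) lies beyond the scatter. Compound 3 `Cc1ccncc1-c1cc(F)cc(-n2nnc(-c3ccccn3)n2)c1` carries 4-methylpyridin-3-yl in place of 2-methylpyridin-3-yl on an aromatic carbon. For the measured compounds named here, no measured step bears directly on this change; the only known step, a 5.1-fold higher number from compound 1 to compound 2 (0.71 log units; beyond the scatter), concerns a different group and gives no direction here. The number for compound 3 is therefore expected to stay within the scatter of compound 2, with no change at the digits printed from compound 2 to compound 3 (within the scatter) as the estimated step. Compound 3 is estimated at 41 nM in this assay, with a range of 15 nM to 120 nM.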

Compound 3, half-maximal inhibitory concentration: 5 nM
For compound 3 the middle estimate is 8.2-fold (0.91 log units) above the measured one; measured number below the stated range.
By their numbers in this assay, from the lowest: compounds 3 and 1 (each within the scatter of the next); then compound 2.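

The methyl group's place on the pyridin-3-yl ring alone moves the result in this assay, with an 8.2-fold lower number from compound 2 to compound 3 (0.91 log units; beyond the scatter) for an exchange that leaves the counted atoms unchanged. The 4-methylpyridin-3-yl group also recovers the level of the 2-aminophenyl group, with a 1.6-fold lower number from compound 1 to compound 3 (0.20 log units; within the scatter), so these two groups cannot be ordered here. No measurement at hand accounts for the effect of moving the methyl group. Still open, on these data alone, is whether an ethyl or a methoxy group in place of this methyl group would hold the number of compound 3.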